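This account rests on a few compounds, and the source may have more. Where it says the series, first, only, none or still open, it means among the compounds named here.

Compound 2 `CCCC[C@H](CCn1cncn1)c1ccc(Cl)cc1` gives the lowest of the two numbers measured in an ADME assay on RD cells (Homo sapiens) for cytotoxicity, read by MTT assay, with a stated time of 3 days (a lower number here means that less compound is tolerated, a higher number that more compound is tolerated), namely 20.3 ug/mL. Compound 1 `CC[C@H](CCn1cncn1)c1ccc(F)cc1` gives 110 ug/mL in this assay, a higher number, but the two compounds differ in more than one place, so no single step can be read from them. Compound 3 `CCCC[C@H](CCn1cncn1)c1ccc(F)cc1` differs from compound 2 by fluoro in place of chloro on an aromatic carbon. No measured step in this assay covers this exchange; a small rise in tolerated concentration, close to the edge of the scatter, is expected, as shown by a 1.7-fold higher number from compound 2 to compound 3 (0.24 log units; within the scatter). Compound 3 is therefore expected to give about 35 ug/mL in this assay, in a range from 15 ug/mL to 80 ug/mL.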

Compound 3, half-maximal cytotoxic concentration: 35.2 ug/mL
Compound 3: the middle estimate sits 1.0-fold (0.00 log units) below what was measured; the range from low to high includes it.
By their numbers in this assay, from the lowest: compounds 2 and 3 (each within the scatter of the next); then compound 1.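

In this assay fluoro in place of chloro on an aromatic carbon gives a 1.7-fold higher number from compound 2 to compound 3 (0.24 log units; within the scatter) and so does not clearly separate the two compounds. Going by these compounds alone, with fluoro present in both compounds, ethyl in place of hydrogen on a saturated chain carbon gives a 3.1-fold lower number from compound 1 to compound 3 (0.49 log units; beyond the scatter) and is the only one of these two steps beyond the scatter. No evidence explains the size of either step. On these data alone, whether bromo on that aromatic carbon or a longer chain on the saturated carbon would change the tolerated concentration stays open.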